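This account rests on a few compounds, and the source may have more. Where it says the series, first, only, none or still open, it means among the compounds named here.

Compound 1 `O=C(/C=C/c1ccc(O)c(O)c1)N1CCN(c2ccccc2F)CC1` gives 2.43 ug/mL
Compound 2 `O=C(/C=C/c1ccc(O)c(O)c1)N1CCN(c2ccccc2Cl)CC1` gives 1.82 ug/mL
Compound 3 `O=C(/C=C/c1ccc(O)c(O)c1)N1CCN(c2cccc(Cl)c2)CC1` gives 1.71 ug/mL

All three values come from a functional assay on B16-F10 cells (Mus musculus) for antiproliferative activity, read by MTT assay, with a stated time of 48 h; on this read-out lower numbers stand for stronger inhibition and higher numbers for weaker inhibition. Compound 2 stands within the scatter of both other compounds, with a 1.3-fold lower number from compound 1 to compound 2 (0.13 log units; within the scatter) on one side and a 1.1-fold lower number from compound 2 to compound 3 (0.03 log units; within the scatter) on the other. The next compound to be measured is compound 4 `COc1ccc(N2CCN(C(=O)/C=C/c3ccc(O)c(O)c3)CC2)cc1`. Its difference from compound 2 is 4-methoxyphenyl in place of 2-chlorophenyl on an amine nitrogen in a ring, with 4-methoxyphenyl in place of 2-chlorophenyl on an amine nitrogen in a ring. Three measured steps change this same group, namely the two above and a 1.4-fold lower number from compound 1 to compound 3 (0.15 log units; within the scatter). None of them involves a 4-methoxyphenyl group, so they offer only indirect guidance. Going by these small steps, no change beyond the scatter is expected in this assay, and no direction is favoured. The step expected is a 1.1-fold higher number from compound 2 to compound 4 (0.04 log units; within the scatter). For compound 4 the estimated value is 2 ug/mL, with an expected range from 1 ug/mL to 4.2 ug/mL.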

Compound 4, half-maximal inhibitory concentration: 1.21 ug/mL
Beside the measured number, compound 4's estimate is 1.7-fold (0.22 log units) above it, and the stated range covers the measured number.
By their numbers in this assay, from the lowest: compounds 4, 3, 2 and 1 (each within the scatter of the next).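

In this assay, among these compounds, 4-methoxyphenyl on the amine nitrogen in the ring is the first group here without a halogen and with a hydrogen-bond acceptor, and every comparison with the halogen-bearing phenyl groups stays within the scatter: a 1.5-fold lower number from compound 2 to compound 4 (0.18 log units; within the scatter), a 1.4-fold lower number from compound 3 to compound 4 (0.15 log units; within the scatter) and a 2.0-fold lower number from compound 1 to compound 4 (0.30 log units; within the scatter). This position therefore accepts a 4-methoxyphenyl group in place of a fluorophenyl or chlorophenyl group with no resolved gain or loss in this read-out. No measurement at hand accounts for these steps. The compounds shown leave open whether an amine, a carboxylic acid or a longer alkoxy chain on this phenyl ring would give a step beyond the scatter. Methoxy and its place on the ring also change together here, and the two cannot be told apart.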